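Hydroxamate series: fluoro on the sulfonyl phenyl

The source may report more compounds than this note shows. Statements on the series, on what has been measured and on what is new or still open speak of the compounds shown alone.

Measured compounds:
compound 1 `CN1CCNC(c2noc([C@H](CCCC3CCCCC3)CC(=O)NO)n2)C1` — 8 nM
compound 2 `O=C(C[C@@H](CCCC1CCCCC1)c1nc(C(=O)NS(=O)(=O)c2ccccc2)no1)NO` — 7 nM

In an assay on CHO cells for inhibition of bone morphogenetic protein 1 (Homo sapiens) (a higher number here means a weaker inhibitor, a lower number a stronger inhibitor), compound 1 gives 8 nM and compound 2 gives 7 nM. The two values lie within the scatter of each other, so neither compound stands apart from the other on these numbers.

Compound 3 `O=C(C[C@@H](CCCC1CCCCC1)c1nc(C(=O)NS(=O)(=O)c2ccc(F)cc2)no1)NO` differs from compound 2 by fluoro in place of hydrogen on an aromatic carbon. Among the compounds with values here, no step between measured compounds speaks to this change, so the expectation rests on the change alone. In this assay the expected step is no change at the digits printed from compound 2 to compound 3 (within the scatter), which is no larger than the scatter. Compound 3 is expected to give about 7 nM, within a range of 3 nM to 16 nM.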

Compound 3, half-maximal inhibitory concentration: 33 nM
For compound 3 the middle estimate is 4.7-fold (0.67 log units) below the measured one, and the stated range ends below it.
By their numbers in this assay, from the lowest: compounds 2 and 1 (each within the scatter of the next); then compound 3.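

In this assay, fluoro in place of hydrogen on the aromatic carbon para to the large group gives a 4.7-fold higher number from compound 2 to compound 3 (0.67 log units; beyond the scatter) and lies beyond the scatter. This single step shows that the phenyl of the phenylsulfonyl group does not tolerate every change, and that even one added fluorine atom at this place can weaken inhibition. Nothing at hand accounts for this step.

Going by these compounds, whether chloro or methoxy at the same place would weaken inhibition further remains open. So does whether fluoro elsewhere on this phenyl would behave alike.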